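Spirooxindole triazole series: aryl swap on the triazole nitrogen

A few compounds are considered here, and "the series" means these few. Any claim that something is new, unique, unknown or untested is made for them only; others in the source may bear on it.

Measured so far:
compound 1 `N#CC1=C(N)Oc2c(N)cc3nc4ccccc4nc3c2C12C(=O)N(Cc1cnnn1-c1ccc(Cl)cc1)c1ccccc12` — > 50000 nM
compound 2 `N#CC1=C(N)Oc2c(N)cc3nc4ccccc4nc3c2C12C(=O)N(Cc1cnnn1-c1cccc(Br)c1)c1ccccc12` — > 50000 nM
compound 3 `N#CC1=C(N)Oc2c(N)cc3nc4ccccc4nc3c2C12C(=O)N(Cc1cnnn1-c1ccc([N+](=O)[O-])cc1)c1ccccc12` — > 50000 nM

All three values in an ADME assay on HUVEC cells (Homo sapiens) for antiproliferative activity, read by MTT assay, with a stated time of 48 h (on this read-out lower numbers stand for stronger inhibition and higher numbers for weaker inhibition), are limits of the assay rather than numbers. Compound 1 gives > 50000 nM in this assay, which is a limit. Compound 2 likewise gives > 50000 nM, a limit. Compound 3 gives > 50000 nM, again a limit. Compound 3 therefore stands at the same limit as the other two, and none of the three can be placed in order against the others.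

The step from compound 3 to compound 4 `CCc1cccc(C)c1-n1nncc1CN1C(=O)C2(C(C#N)=C(N)Oc3c(N)cc4nc5ccccc5nc4c32)c2ccccc21` is 2-ethyl-6-methylphenyl in place of 4-nitrophenyl on an aromatic nitrogen. Of the measured steps, a step that the two limits leave unreadable from compound 1 to compound 2, a step that the two limits leave unreadable from compound 1 to compound 3 and a step that the two limits leave unreadable from compound 2 to compound 3 all touch the same aryl group on the triazole nitrogen, yet none is readable, since (the limit of > 50000 nM in this assay, at which 3 of the 3 values shown sit). For the measured compounds named here, no measured step therefore tells whether swapping the aryl group moves the read-out at all; the only pattern seen is that every aryl variant so far has sat at the limit.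

On that basis compound 4 is expected to stay at the limit as well, with the estimated step that the limit leaves unreadable from compound 3 to compound 4 reflecting no expected change beyond the scatter. The estimate for compound 4 in this assay is 60000 nM, with a range of 30000 nM to 150000 nM.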

Compound 4, half-maximal inhibitory concentration: > 50000 nM
Compound 4 gave a limit, no number; the forecaster's own chance of this, stated with the estimate: 85%; the middle value is on the limit's open side.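

In this assay compound 4 gives > 50000 nM, which is a limit. The steps joining compound 4 to compound 1, compound 2 and compound 3 therefore cannot be read: the limit of > 50000 nM in this assay, at which 4 of the 4 values shown sit.

The compounds shown leave open whether changing the aryl group on the aromatic nitrogen moves this read-out at all.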